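This account rests on a few compounds, and the source may have more. Where it says the series, first, only, none or still open, it means among the compounds named here.

Series notes. Compound 1 `CC(C)[C@@H]1CC[C@@H](C)C[C@@]12N(C)C(=O)[C@@H]1[C@H]3C(=O)NC(=O)[C@H]3ON12` gives 1550 ug/mL in a functional assay, with a stated time of 20 min; a higher number here means a weaker inhibitor, a lower number a stronger inhibitor; compound 2 `CC(C)[C@@H]1CC[C@@H](C)C[C@@]12N(C)C(=O)[C@@H]1[C@H]3C(=O)N(C)C(=O)[C@H]3ON12` gives 1650 ug/mL in this assay; compound 3 `CC(C)[C@@H]1CC[C@@H](C)C[C@@]12N(C)C(=O)[C@@H]1[C@H]3C(=O)N(c4ccccc4)C(=O)[C@H]3ON12` gives 900 ug/mL in this assay. Compound 3 holds the lowest of the three numbers, yet both steps to it, a 1.7-fold lower number from compound 1 to compound 3 (0.24 log units; within the scatter) and a 1.8-fold lower number from compound 2 to compound 3 (0.26 log units; within the scatter), stay within the scatter, as does a 1.1-fold higher number from compound 1 to compound 2 (0.03 log units; within the scatter). Compound 4 `CC(C)[C@@H]1CC[C@@H](C)C[C@@]12N(C)C(=O)[C@@H]1[C@H]3C(=O)N(c4ccc(Cl)cc4)C(=O)[C@H]3ON12` carries the change (chloro in place of hydrogen on an aromatic carbon). Going by the values given here, none of the measured steps touches the six-membered aromatic ring of carbon only; all three concern the amide-type nitrogen in a ring and none left the scatter. Nothing in the series therefore points to a step beyond the scatter in this assay, in either direction. For compound 4 the expected number is 800 ug/mL, estimated between 400 ug/mL and 1600 ug/mL. The step expected is a 1.1-fold lower number from compound 3 to compound 4 (0.05 log units; within the scatter).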

Compound 4, half-maximal inhibitory concentration: 2150 ug/mL
The estimate for compound 4 lay 2.7-fold (0.43 log units) below the measured number; measured number above the stated range.
By their numbers in this assay, from the lowest: compounds 3, 1, 2 and 4 (each within the scatter of the next, the first and the last beyond it).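

Chloro on the aromatic carbon gives the first single change in the series to leave the scatter: a 2.4-fold higher number from compound 3 to compound 4 (0.38 log units; beyond the scatter) in the direction of a weaker inhibitor. Going by these compounds alone, the 4-chlorophenyl group stays within the scatter against the smaller nitrogen substituents, with a 1.3-fold higher number from compound 2 to compound 4 (0.11 log units; within the scatter) and a 1.4-fold higher number from compound 1 to compound 4 (0.14 log units; within the scatter) as the two readings, so only the pair of compound 3 and compound 4 separates. No measurement here bears on the reason for this result.

From the compounds shown here alone, whether the step belongs to chloro alone stays open. Methoxy, an amine or a carboxylic acid at this place on the phenyl ring could show it.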